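Methyl Ester Variant of the Pyridyl Acid

The source may hold more compounds than are shown below. What is called first, only, known or untested is meant among the compounds shown, and "the series" means these compounds.

Compound 3 `O=C(O)c1cc(-c2cnc(C(=O)CCc3ccc(-c4ccccc4)cc3)o2)ccn1` stands at the high end of the three numbers measured in an assay for inhibition of Fatty-acid amide hydrolase 1 (Rattus norvegicus); on this read-out lower numbers stand for stronger inhibition and higher numbers for weaker inhibition: compound 3 gives 50 nM. Compound 1 `O=C(O)c1ccc(-c2cnc(C(=O)CCc3ccc(-c4ccccc4)cc3)o2)cn1` gives 44 nM in this assay, and the step of a 1.1-fold higher number from compound 1 to compound 3 (0.06 log units; within the scatter). Compound 2 `CS(=O)(=O)c1cnc(C(=O)CCc2ccc(-c3ccccc3)cc2)o1` gives 1.2 nM, and the step of a 42-fold higher number from compound 2 to compound 3 (1.62 log units; beyond the scatter).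

Compound 4 `COC(=O)c1ccc(-c2cnc(C(=O)CCc3ccc(-c4ccccc4)cc3)o2)cn1` has not yet been measured; it carries 6-(methoxycarbonyl)pyridin-3-yl in place of 2-carboxypyridin-4-yl on an aromatic carbon. Two things change at once: the pyridyl group returns to the form seen in compound 1, and the acid becomes its methyl ester. The first part is covered by the step of a 1.1-fold higher number from compound 1 to compound 3 (0.06 log units; within the scatter), which lay within the scatter. Among the measured compounds shown here, no measured pair sets an acid against its ester, so that part is open. The step of a 37-fold lower number from compound 1 to compound 2 (1.56 log units; beyond the scatter) shows that the group on that aromatic carbon can move the number a great deal, but the methylsulfonyl is a different kind of change. Compound 4 is therefore expected to show a step of a 1.7-fold lower number from compound 3 to compound 4 (0.22 log units; within the scatter). The estimate for compound 4 is 30 nM, in a range from 8 nM to 120 nM.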

Compound 4, inhibition constant: 0.6 nM
The estimate for compound 4 lay 50-fold (1.70 log units) above the measured number, and the stated range ends above it.
By their numbers in this assay, from the lowest: compounds 4 and 2 (each within the scatter of the next); then compounds 1 and 3 (each within the scatter of the next).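

Methyl in place of hydrogen on the acid of compound 1 gives a 73-fold lower number from compound 1 to compound 4 (1.87 log units; beyond the scatter) in this assay, the first pair shown to set an acid against its ester, so this single change outweighs the move between the two carboxypyridinyl forms, which stayed within the scatter. The change from the other acid is of similar size, with an 83-fold lower number from compound 3 to compound 4 (1.92 log units; beyond the scatter) as the step, and a 2.0-fold lower number from compound 2 to compound 4 (0.30 log units; within the scatter) as the step from the methylsulfonyl group shows that a pyridyl group on this carbon of the five-membered aromatic ring can match methylsulfonyl once it carries the methyl ester. Nothing measured here accounts for the size of the step from acid to ester. The compounds shown leave open whether an ester on the 2-carboxypyridin-4-yl form would behave as compound 4 does. They also leave open whether an ethyl ester or a primary amide in place of the methyl ester would hold the same number.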